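Pyridin-2-yl to 4-bromophenyl on the triazole: an expected limit

The compounds below may be only part of what the source reports. "The series", "measured", "known", "first", "only" and "open" are said of these compounds alone.

Measured compounds:
compound 1 `Cc1ccc(S(=O)(=O)Oc2ccc3c(c2C)[C@H](Cn2cc(-c4ccccc4)nn2)[C@@]24CC(=O)[C@@](C)(CC[C@@H]32)C4)cc1` — > 20000 nM
compound 2 `Cc1ccc(S(=O)(=O)Oc2ccc3c(c2C)[C@H](Cn2cc(-c4ccccn4)nn2)[C@@]24CC(=O)[C@@](C)(CC[C@@H]32)C4)cc1` — > 20000 nM

In a functional assay on MCF7 cells (Homo sapiens) for cytotoxicity, read by MTT assay, with a stated time of 4 days (on this read-out lower numbers stand for stronger inhibition and higher numbers for weaker inhibition), compound 1 gives > 20000 nM, which is a limit of the assay and not a number. In this assay compound 2 gives > 20000 nM, likewise a limit. The step that the two limits leave unreadable from compound 1 to compound 2 is therefore unreadable. Compound 2 stands at the limit of > 20000 nM in this assay, at which 2 of the 2 values shown sit, with no numbered value shown for it. Compound 3 `Cc1ccc(S(=O)(=O)Oc2ccc3c(c2C)[C@H](Cn2cc(-c4ccc(Br)cc4)nn2)[C@@]24CC(=O)[C@@](C)(CC[C@@H]32)C4)cc1` differs from compound 2 by 4-bromophenyl in place of pyridin-2-yl on an aromatic carbon. Within the data shown here, the only measured step, from compound 1 to compound 2, bears on this change in that it also exchanges one six-membered aromatic ring for another at the same place, and both ends of that step sit at the limit. In this assay no step beyond the scatter is expected from compound 2 to compound 3, and the reading is expected once more to stop at a limit. Compound 3 is expected to give 20000 nM, with a range from 8000 nM to 50000 nM. The estimated step of a number no higher from compound 2 to compound 3 (the limit leaves the size open) is thus expected to be none beyond the scatter.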

Compound 3, half-maximal inhibitory concentration: > 20000 nM
Compound 3 was reported as a limit (the forecaster's own chance of this, stated with the estimate: 80%); the middle value lies on the limit itself.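

In this assay compound 3 gives > 20000 nM, again a limit and not a number, so the steps among compound 1, compound 2 and compound 3 cannot be read. The compounds shown leave open whether the group on the triazole changes the read-out at all: the limit of > 20000 nM in this assay, at which 3 of the 3 values shown sit.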